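Changing the Aryl Group on the Aromatic Nitrogen

The compounds below may be only part of what the source reports. "The series", "measured", "known", "first", "only" and "open" are said of these compounds alone.

In a functional assay on HepG2 cells (Homo sapiens) for inhibition, read by MTT assay, with a stated time of 72 h (a higher number here means a weaker inhibitor, a lower number a stronger inhibitor), compound 1 `COc1ccccc1-n1c(-c2coc3cc(C)c(Cl)cc3c2=O)nc(-c2ccccc2)c1-c1ccccc1` gives 12500 nM, the highest of the two numbers measured. For the measured compounds named here, its only measured neighbour, compound 2 `Cc1cccc(-n2c(-c3coc4cc(C)c(Cl)cc4c3=O)nc(-c3ccccc3)c2-c2ccccc2)c1`, gives 6250 nM, and the step of a 2.0-fold lower number from compound 1 to compound 2 (0.30 log units; within the scatter) exchanges one aryl group on the aromatic nitrogen for another without leaving the scatter. Compound 3 `Cc1cc2occ(-c3nc(-c4ccccc4)c(-c4ccccc4)n3-c3ccc(Br)cc3)c(=O)c2cc1Cl` differs from compound 1 by 4-bromophenyl in place of 2-methoxyphenyl on an aromatic nitrogen. Going by the values given here, because the one comparable step is a 2.0-fold lower number from compound 1 to compound 2 (0.30 log units; within the scatter), compound 3 is expected to show a 1.3-fold lower number from compound 1 to compound 3 (0.10 log units; within the scatter), nothing beyond the scatter. Compound 3 is therefore estimated at 10000 nM, within a range from 4000 nM to 25000 nM.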

Compound 3, half-maximal inhibitory concentration: 6250 nM
Estimate against measurement, compound 3: 1.6-fold (0.20 log units) above, and the stated range covers the measured number.
By their numbers in this assay, from the lowest: compounds 2, 3 and 1 (each within the scatter of the next).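

In this assay the exchange for 4-bromophenyl on the aromatic nitrogen gives a 2.0-fold lower number from compound 1 to compound 3 (0.30 log units; within the scatter) when it replaces 2-methoxyphenyl and no change at the digits printed from compound 2 to compound 3 (within the scatter) when it replaces 3-methylphenyl. The three aryl groups at this position thus stand within the scatter of one another, whether the ring carries methoxy, methyl or bromine. Nothing measured here accounts for this.

The compounds shown leave open whether a phenyl carrying an amine or a carboxylic acid, or a longer chain in place of the ring, would read differently. They also leave open whether any change at this position can move the number beyond the scatter.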